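Nitro on the triazole phenyl of a cinnamic acid

This account rests on a few compounds, and the source may have more. Where it says the series, first, only, none or still open, it means among the compounds named here.

Among the compounds with values here, compound 1 `COc1ccc(/C=C\C(=O)O)c(OCc2cn(-c3ccccc3)nn2)c1CC=C(C)C` is the only compound with a number here: in a functional assay on T47D cells (Homo sapiens) for cytotoxicity, read by MTT assay, with a stated time of 24 h (on this read-out higher numbers stand for weaker inhibition and lower numbers for stronger inhibition), compound 1 gives 34100 nM. A related compound 2 `COc1ccc(-n2cc(COc3c(/C=C\C(=O)O)ccc(OC)c3CC=C(C)C)nn2)cc1` carries a methoxy-bearing phenyl, but in this assay compound 2 gives "not determined" (no result reported), so no result was reported for it. Compound 3 `COc1ccc(/C=C\C(=O)O)c(OCc2cn(-c3cccc([N+](=O)[O-])c3)nn2)c1CC=C(C)C` differs from compound 1 by nitro in place of hydrogen on an aromatic carbon, read one bond further out as phenyl to 3-nitrophenyl. Within the data shown here, no measured pair shows the effect of such a change, so the expected step from compound 1 to compound 3 in this assay is a 1.4-fold lower number from compound 1 to compound 3 (0.13 log units; within the scatter), small and within the scatter. Compound 3 is therefore estimated at 25000 nM, with a range from 8000 nM to 80000 nM.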

Compound 3, half-maximal inhibitory concentration: 15400 nM
The estimate for compound 3 lay 1.6-fold (0.21 log units) above the measured number; the measured number falls inside the stated range.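

Within the data shown here, replacing hydrogen with nitro on the phenyl of compound 1 gives the first measured step at this position: in this assay the change gives a 2.2-fold lower number from compound 1 to compound 3 (0.35 log units; beyond the scatter) and this is modest but beyond the scatter. The phenyl on the triazole therefore accepts a nitro group here without a rise in the number. Nothing available gives a cause for this step.

As far as these compounds go, whether an amine or a nitrile on this phenyl would shift the number in the same direction remains open. Compound 2 has no reported result, so its steps cannot be read.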